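Methoxy Added to a Compound at the Assay Limit

This account rests on a few compounds, and the source may have more. Where it says the series, first, only, none or still open, it means among the compounds named here.

Compound 1 `Cc1cccc(NNS(=O)(=O)c2ccc(S(C)(=O)=O)cc2)c1` gave 7850 nM
Compound 2 `Cc1cccc(NNS(=O)(=O)c2ccc(C#N)cc2)c1` gave 3400 nM
Compound 3 `CC(=O)Nc1ccc(S(=O)(=O)NNc2ccccc2)cc1` gave > 10000 nM

All three numbers come from an assay on HeLa cells for inhibition of Indoleamine 2,3-dioxygenase 1 (Homo sapiens), read by spectrophotometry, with a stated time of 24 h; on this read-out higher numbers stand for an effect only at larger amounts of compound and lower numbers for an effect already at smaller amounts. Compound 3 stands at the edge of what was measured: its result is a limit of the assay and not a number, (the limit of > 10000 nM in this assay, at which 1 of the 3 values shown sits). Within the data shown here, compound 1 and compound 2 both gave numbers, and the single step between them, a 2.3-fold lower number from compound 1 to compound 2 (0.36 log units; beyond the scatter), is a change on the ring that carries the sulfonyl group, at the aromatic carbon bearing the methylsulfonyl or the cyano group.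

Compound 4 `COc1ccc(NNS(=O)(=O)c2ccc(NC(C)=O)cc2)cc1` has not been measured. It differs from compound 3 by methoxy in place of hydrogen on an aromatic carbon. Among the measured compounds shown here, no measured step touches that ring or that kind of substituent; the only measured step, a 2.3-fold lower number from compound 1 to compound 2 (0.36 log units; beyond the scatter), lies on the other ring and is modest in size. What is known of compound 3 is only its limit (the limit of > 10000 nM in this assay, at which 1 of the 3 values shown sits).

The step that the limit leaves unreadable from compound 3 to compound 4 is therefore expected to be small, with no clear direction. Compound 4 is estimated at 15000 nM, within a range from 5000 nM to 40000 nM, and with a real chance that the assay again reports only a limit.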

Compound 4, half-maximal effective concentration: > 10000 nM
Compound 4 was reported as a limit; the forecaster's own chance of this, stated with the estimate: 60%; the middle value does not contradict the limit.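

In this assay compound 3 gives > 10000 nM as a limit of the assay and not a number. Compound 4 gives > 10000 nM as a limit too. Among these compounds, no step from compound 3 to compound 4 can be read, since both stand at the same limit: the limit of > 10000 nM in this assay, at which 2 of the 4 values shown sit. Going by these compounds, whether methoxy in place of hydrogen changes the read-out at all stays open.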